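Methyl in place of hydrogen: three limits and one estimate

The compounds below may be only part of what the source reports. "The series", "measured", "known", "first", "only" and "open" are said of these compounds alone.

Working notes on a series of three measured compounds and one still to be measured in an ADME assay on microsomes from liver (Homo sapiens) for metabolic stability; a lower number here means slower removal, a higher number faster removal of the compound.

Compound 1 `CC(C)Oc1cc(Oc2ccc(S(C)(=O)=O)cc2)cc(-c2nccc(=O)[nH]2)c1` gives < 9.8 mL/min/kg in this assay, which is a limit of the assay and not a number.
Compound 2 `Cc1cnc(-c2cc(Oc3ccc(S(C)(=O)=O)cc3)cc(OC(C)C)c2)[nH]c1=O` gives < 8 mL/min/kg in this assay, again a limit.
Compound 3 `CC(C)Oc1cc(Oc2cnc(C(=O)N(C)C)nc2)cc(-c2nccc(=O)[nH]2)c1` gives < 8 mL/min/kg in this assay, also a limit.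

Among the compounds with values here, the one change made twice is methyl in place of hydrogen on an aromatic carbon. From compound 1 to compound 2 it gives a step that the two limits leave unreadable from compound 1 to compound 2. Both values sit at the edge of what this assay can report, so the size of that step cannot be read; what can be said is that the limit of < 8 mL/min/kg in this assay, at which 2 of the 3 values shown sit, and the limit of < 9.8 mL/min/kg in this assay, at which 1 of the 3 values shown sits, hold every measurement so far.

Compound 3 carries a different core; the difference between the core of compound 1 and the core of compound 3 is not broken down here.

Compound 4 `Cc1cnc(-c2cc(Oc3cnc(C(=O)N(C)C)nc3)cc(OC(C)C)c2)[nH]c1=O` is still to be measured. It differs from compound 3 by methyl in place of hydrogen on an aromatic carbon, the same change as that from compound 1 to compound 2.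

The expectation for the step from compound 3 to compound 4 in this assay is a step that the limit leaves unreadable from compound 3 to compound 4, resting on compound 1 and compound 2 both staying within the limit of < 9.8 mL/min/kg in this assay, at which 1 of the 3 values shown sits, and (the limit of < 8 mL/min/kg in this assay, at which 2 of the 3 values shown sit). The estimate for compound 4 is 6 mL/min/kg, with a range from 3 mL/min/kg to 12 mL/min/kg, and a further limit rather than a number is the likelier outcome.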

Compound 4, clearance in the Homo sapiens assay: < 8 mL/min/kg
Compound 4 was reported as a limit (the forecaster's own chance of this, stated with the estimate: 75%); the middle value lies beyond the limit too.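

In the Homo sapiens assay compound 3 gives < 8 mL/min/kg, which is a limit and not a number. In the Homo sapiens assay compound 4 gives < 8 mL/min/kg, also a limit and not a number, so no step can be read between the two. The compounds shown leave open how large a change in clearance, if any, methyl in place of hydrogen on an aromatic carbon brings in either pair, compound 1 and compound 2 or compound 3 and compound 4.

In a physicochemical assay for solubility, in phosphate buffer, measured as kinetic solubility, with a stated time of 24 h, at pH 6.5 (on this read-out lower numbers stand for lower solubility and higher numbers for higher solubility), compound 3 gives 332000 nM and compound 4 gives 218000 nM. In the physicochemical assay methyl in place of hydrogen on an aromatic carbon gives a 1.5-fold lower number from compound 3 to compound 4 (0.18 log units; within the scatter).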